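Amide group swap from compound 3 to compound 4

This account rests on a few compounds, and the source may have more. Where it says the series, first, only, none or still open, it means among the compounds named here.

In a functional assay on MCF7 cells (Homo sapiens) for antiproliferative activity, read by MTT assay, with a stated time of 72 h (a higher number here means a weaker inhibitor, a lower number a stronger inhibitor), compound 1 `CCN1CCN(c2cc(C)c3cc(NC(=O)c4cccc(C)c4)ccc3n2)CC1` gives 7800 nM, compound 2 `CCN1CCN(c2cc(C)c3cc(NC(=O)c4cc(Cl)cc(Cl)c4)ccc3n2)CC1` gives 6090 nM and compound 3 `CCN1CCN(c2cc(C)c3cc(NC(=O)c4ccc5ccccc5n4)ccc3n2)CC1` gives 7060 nM. Compound 3 stands within the scatter of both others, as shown by a 1.1-fold lower number from compound 1 to compound 3 (0.04 log units; within the scatter) and a 1.2-fold higher number from compound 2 to compound 3 (0.06 log units; within the scatter). The next change leads to compound 4 `CCN1CCN(c2cc(C)c3cc(NC(=O)c4ccc(OC)cc4)ccc3n2)CC1`: 4-methoxyphenyl in place of quinolin-2-yl on a carbonyl carbon. All measured steps at this place bear on it, and a 1.3-fold lower number from compound 1 to compound 2 (0.11 log units; within the scatter) also stays within the scatter. Within the data shown here, no measured compound carries 4-methoxyphenyl, so the basis is limited. An estimated 1.0-fold lower number from compound 3 to compound 4 (0.00 log units; within the scatter) is expected, meaning no step beyond the scatter. For compound 4 the expected value is 7000 nM, with an estimated range of 3500 nM to 14000 nM.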

Compound 4, half-maximal inhibitory concentration: 7690 nM
For compound 4 the middle estimate is 1.1-fold (0.04 log units) below the measured one; low and high end bracket the measured number.
By their numbers in this assay, from the lowest: compounds 2, 3, 4 and 1 (each within the scatter of the next).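

In this assay the 4-methoxyphenyl group gives a 1.1-fold higher number from compound 3 to compound 4 (0.04 log units; within the scatter) and a 1.3-fold higher number from compound 2 to compound 4 (0.10 log units; within the scatter) and also a 1.0-fold lower number from compound 1 to compound 4 (0.01 log units; within the scatter) as its three new steps. Among these compounds, an oxygen-bearing group on the carbonyl carbon thus joins 3-methylphenyl, 3,5-dichlorophenyl and quinolin-2-yl, with no pair of the four separated beyond the scatter. No available data bear on why these groups read alike.

As far as these compounds go, whether an amine, a carboxylic acid or a longer alkyl chain at this carbonyl carbon would give a step beyond the scatter remains open. So does the effect of any change on the shared core.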